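The compounds below may be only part of what the source reports. "The series", "measured", "known", "first", "only" and "open" are said of these compounds alone.

Working notes on the benzoxazole-free description of the series: all three measured compounds share a core, shown as `O=S(=O)(Nc1ccc2oc(-c3ccccc3)nc2c1)c1ccc(Cl)cc1` for compound 1, carrying a sulfonamide on an aromatic carbon. Compound 1 bears a 4-chlorophenyl on the sulfonyl sulfur. In an assay on cells for inhibition of HSP60/HSP10 (Homo sapiens), with a stated time of 60 min (a lower number here means a stronger inhibitor, a higher number a weaker inhibitor), compound 1 reaches only the upper limit of the assay, > 100000 nM. Compound 2, `O=S(=O)(Nc1ccc2oc(-c3ccccc3)nc2c1)c1ccccc1Cl`, bears a 2-chlorophenyl on the same sulfur. In this assay compound 2 likewise stops at the limit, > 100000 nM. Compound 3, `CCc1ccc(S(=O)(=O)Nc2ccc3oc(-c4ccccc4)nc3c2)cc1`, carries a 4-ethylphenyl there, ethyl in place of chloro on an aromatic carbon. In this assay compound 3 also gives the limit, > 100000 nM. Compound 3 therefore stands nowhere in particular on the numbers shown: every value in the series sits at the limit of > 100000 nM in this assay, at which 3 of the 3 values shown sit, so a step that the two limits leave unreadable from compound 1 to compound 2, a step that the two limits leave unreadable from compound 1 to compound 3 and a step that the two limits leave unreadable from compound 2 to compound 3 cannot be sized.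

Compound 4, `CS(=O)(=O)Nc1ccc2oc(-c3ccccc3)nc2c1`, introduces (methyl in place of 4-ethylphenyl on a sulfonyl sulfur). All three measured steps bear on the sulfonyl substituent, and none gives a readable size, so no direction can be drawn from them. With no active anchor anywhere in the series, compound 4 is expected to remain at the limit as well, an expected step that the limit leaves unreadable from compound 3 to compound 4 not distinguishable from none. The estimate for compound 4 in this assay is 150000 nM, with a range from 30000 nM to 1000000 nM.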

Compound 4, half-maximal inhibitory concentration: > 100000 nM
Compound 4: a limit, no number; the forecaster's own chance of this, stated with the estimate: 85%; the middle value lies beyond the limit too.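

In this assay, among the compounds shown here, compound 4 gives only a limit, > 100000 nM, so no step from compound 1, compound 2 or compound 3 to compound 4 can be read. All four compounds now share one limit: the limit of > 100000 nM in this assay, at which 4 of the 4 values shown sit.

The compounds shown leave open whether any substituent on the sulfonyl sulfur gives a measurable inhibition in this assay.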